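Fluoro for Methoxy on an Aryl Carbamate Selenocyanate

The source may report more compounds than this note shows. Statements on the series, on what has been measured and on what is new or still open speak of the compounds shown alone.

Compound 1 `COc1ccc(OC(=O)Nc2ccc([Se]C#N)cc2)cc1` was tested in a functional assay on HT-29 cells (Homo sapiens) for cytotoxicity, read by MTT assay, with a stated time of 72 h (on this read-out higher numbers stand for weaker inhibition of growth and lower numbers for stronger inhibition of growth), and gave 13600 nM. Within the data shown here, of the two compounds measured so far, compound 1 has the lower number; compound 2 `CCCOC(=O)Nc1ccc([Se]C#N)cc1` gives 28400 nM in this assay, a value that lies a little beyond the usual scatter from that of compound 1. Among the measured compounds shown here, these two differ in more than one place, so no single step connects them. The new compound, compound 3 `N#C[Se]c1ccc(NC(=O)Oc2ccc(F)cc2)cc1`, differs from compound 1 in one position only: fluoro in place of methoxy on an aromatic carbon, para to a large group. For the measured compounds named here, no measured pair in this set shows such an exchange, so nothing here fixes the size of the step. The step of a 1.2-fold higher number from compound 1 to compound 3 (0.07 log units; within the scatter) is expected to stay within the usual scatter, in either direction. The estimate for compound 3 in this assay is 16000 nM, in a range from 7000 nM to 40000 nM.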

Compound 3, concentration for 50% growth inhibition: 8800 nM
The estimate for compound 3 lay 1.8-fold (0.26 log units) above the measured number; measured number inside the range.
By their numbers in this assay, from the lowest: compounds 3 and 1 (each within the scatter of the next); then compound 2.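

In this assay, fluoro in place of methoxy on an aromatic carbon, para to a large group, gives a 1.5-fold lower number from compound 1 to compound 3 (0.19 log units; within the scatter). Among these compounds, this is the first step in the set that isolates a single position, and it shows that the assay does not separate these two groups here, even though the exchange removes the carbon and oxygen of methoxy along with its hydrogen-bond acceptor. Nothing measured here offers a reason for this result.

The compounds shown leave open whether an amine or a carboxylic acid at this position would move the number beyond the scatter. They also leave open whether fluoro and methoxy would read alike at another place on the same ring, since this single step speaks for one position only.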